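This account rests on a few compounds, and the source may have more. Where it says the series, first, only, none or still open, it means among the compounds named here.

In a functional assay on HOP-62 cells (Homo sapiens) for inhibition, read by sulforhodamine B assay (on this read-out higher numbers stand for weaker inhibition of growth and lower numbers for stronger inhibition of growth), compound 1 `Cc1ccc2[nH]c(-c3ccc(-c4ccc(-c5ccc(N(C)C)cc5)cc4)cc3)nc2c1` gives 4230 nM, compound 2 `FC(F)(F)c1ccc(-c2ccc(-c3ccc(-c4nc5ccccc5[nH]4)cc3)cc2)cc1` gives 100000 nM, and compound 3 `Oc1cccc2[nH]c(-c3ccc(-c4ccc(-c5ccc(C(F)(F)F)cc5)cc4)cc3)nc12` gives 3200 nM. Compound 3 therefore sits level with compound 1, as their two values lie within the scatter of each other, while compound 2 shows a far higher number.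

Compound 4 `Oc1cccc2[nH]c(-c3ccc(-c4ccc(-c5cccc(Cl)c5)cc4)cc3)nc12` keeps the hydroxy of compound 3 but exchanges another group: 3-chlorophenyl in place of 4-(trifluoromethyl)phenyl on an aromatic carbon. In words, 3-chlorophenyl stands in place of 4-(trifluoromethyl)phenyl on an aromatic carbon.

Within the data shown here, only one measured step links two compounds that differ in a single place, a 31-fold lower number from compound 2 to compound 3 (1.49 log units; beyond the scatter), and it is large. That step, however, records hydroxy in place of hydrogen on an aromatic carbon. Among the measured compounds shown here, compound 4 retains that hydroxy, so the step does not measure the present exchange, and no measured pair shows this exchange alone.

With no evidence for a shift in either direction, the best guide in this assay is compound 3 itself at 3200 nM, and no step beyond the scatter is expected. The expected change is a 1.1-fold higher number from compound 3 to compound 4 (0.04 log units; within the scatter). For compound 4 the estimated value is 3500 nM, with an expected range from 1200 nM to 12000 nM.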

Compound 4, concentration for 50% growth inhibition: 2260 nM
The estimate for compound 4 lay 1.5-fold (0.19 log units) above the measured number; measured number inside the range.
By their numbers in this assay, from the lowest: compounds 4, 3 and 1 (each within the scatter of the next); then compound 2.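

In this assay the exchange gives a 1.4-fold lower number from compound 3 to compound 4 (0.15 log units; within the scatter), so compound 3 and compound 4 cannot be told apart, even though 3-chlorophenyl differs from 4-(trifluoromethyl)phenyl in both its substituent and that substituent's place on the ring. Among these compounds, this is the first sign that, with the hydroxy kept, this place on the aromatic carbon accepts more than one substituted phenyl group without a step beyond the scatter, whereas the only earlier step spoke about the hydroxy alone. No measurement is available to explain why the two groups behave alike here.

A single exchange alters the substituent and its place together, so the compounds shown cannot separate the two, and they leave open whether 3-chlorophenyl would give a similar number without the hydroxy. From the compounds shown here alone, it also remains open whether the level result would hold for a phenyl group carrying a carboxylic acid or a primary amide, which differ more from the two groups compared here.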